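An ester replaces fluoro at the assay limit

The source may hold more compounds than are shown below. What is called first, only, known or untested is meant among the compounds shown, and "the series" means these compounds.

Compound 3 `O=C1COc2ccc(F)cc2N1Cc1cn(Cc2ccccc2)nn1` gives > 100000 nM in a functional assay on HT-29 cells (Homo sapiens) for cytotoxicity, read by MTT assay, with a stated time of 6 days (a higher number here means a weaker inhibitor, a lower number a stronger inhibitor), as a limit, not a number. Compound 1 `Cc1ccc2c(c1)N(Cc1cn(Cc3ccccc3)nn1)C(=O)CO2` gives > 100000 nM in this assay, also a limit. For the measured compounds named here, compound 2 `O=C1COc2ccc(Cl)cc2N1Cc1cn(Cc2ccccc2)nn1` gives 76500 nM as the only actual number so far. Compound 4 `CCOC(=O)c1ccc2c(c1)N(Cc1cn(Cc3ccccc3)nn1)C(=O)CO2` carries ethoxycarbonyl in place of fluoro on an aromatic carbon. Two earlier steps at that carbon are an at least 1.3-fold lower number from compound 1 to compound 2 (0.11 log units; that floor lies within the scatter) and an at least 1.3-fold higher number from compound 2 to compound 3 (0.11 log units; that floor lies within the scatter), while a step that the two limits leave unreadable from compound 1 to compound 3 cannot be sized. Going by the values given here, no measured step brings in ethoxycarbonyl. The values shown so far sit mostly at the limit of > 100000 nM in this assay, at which 2 of the 3 values shown sit, so no step beyond the scatter is expected in this assay. The expected step is an at least 1.1-fold lower number from compound 3 to compound 4 (0.04 log units; that floor lies within the scatter), with no firm direction. Compound 4 is estimated at 90000 nM, within 35000 nM to 200000 nM, and may report only a limit.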

Compound 4, half-maximal inhibitory concentration: 41500 nM
Compound 4: the middle estimate sits 2.2-fold (0.34 log units) above what was measured; the range from low to high includes it.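

In this assay, for the compounds shown here, ethoxycarbonyl at this aromatic carbon gives the first steps that lie beyond the scatter, an at least 2.4-fold lower number from compound 3 to compound 4 (0.38 log units; beyond the scatter) and an at least 2.4-fold lower number from compound 1 to compound 4 (0.38 log units; beyond the scatter). Against the chloro of compound 2 there is no such separation, with a 1.8-fold lower number from compound 2 to compound 4 (0.27 log units; within the scatter), so this carbon tolerates the larger ester without a loss, though chloro reads much the same. Even so, the series stays close to its ceiling: the limit of > 100000 nM in this assay, at which 2 of the 4 values shown sit.

On these data alone, how a carboxylic acid, an amine or a longer ester chain at this carbon would read remains open.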